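Amide cap variation on the shared core: compound 3

A few compounds are considered here, and "the series" means these few. Any claim that something is new, unique, unknown or untested is made for them only; others in the source may bear on it.

Measured in a functional assay on U2OS cells for antagonist activity at proto-oncogene Wnt-3 (Homo sapiens), read by a luciferase reporter, with a stated time of 18 h; on this read-out lower numbers stand for an effect already at smaller amounts and higher numbers for an effect only at larger amounts of compound:
compound 1 `CN(C)CC(=O)N1CCC(NS(=O)(=O)c2cc(S(=O)(=O)c3ccccc3)ccc2C(F)(F)F)CC1`: 280 nM
compound 2 `O=C1CC[C@@H](C(=O)N2CCC(NS(=O)(=O)c3cc(S(=O)(=O)c4ccccc4)ccc3C(F)(F)F)CC2)N1`: 240 nM

Compound 2 holds the lowest of the two numbers, but the step of a 1.2-fold lower number from compound 1 to compound 2 (0.07 log units; within the scatter) is within the scatter, so the two compounds are not separated. Compound 3 `CC(C)(C)C(=O)N1CCC[C@H]1C(=O)N1CCC(NS(=O)(=O)c2cc(S(=O)(=O)c3ccccc3)ccc2C(F)(F)F)CC1` carries the change (1-((tert-butyl)carbonyl)pyrrolidin-2-yl in place of 5-oxopyrrolidin-2-yl on a carbonyl carbon). Within the data shown here, the only measured step at that carbonyl carbon, a 1.2-fold lower number from compound 1 to compound 2 (0.07 log units; within the scatter), was small, so the cap at this place has so far not moved the read-out beyond the scatter. For compound 3 a step of a 1.3-fold higher number from compound 2 to compound 3 (0.10 log units; within the scatter) is therefore expected, that is, no change beyond the scatter. Compound 3 is estimated at 300 nM, range 100 nM to 900 nM.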

Compound 3, half-maximal effective concentration: 270 nM
For compound 3 the middle estimate is 1.1-fold (0.05 log units) above the measured one; measured number inside the range.
By their numbers in this assay, from the lowest: compounds 2, 3 and 1 (each within the scatter of the next).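

The step of a 1.1-fold higher number from compound 2 to compound 3 (0.05 log units; within the scatter) and the step of a 1.0-fold lower number from compound 1 to compound 3 (0.02 log units; within the scatter) both stay within the scatter, even though the cap grows from 6 to 11 heavy atoms and goes from 1 hydrogen-bond donor to 0. On this carbonyl carbon, three different caps therefore remain unseparated in this assay, and the 1-((tert-butyl)carbonyl)pyrrolidin-2-yl group is tolerated as well as the smaller caps. No evidence is available on what lies behind this flat read-out.

As far as these compounds go, it remains open whether a carboxylic acid or a longer alkyl chain on this carbonyl carbon would move the read-out beyond the scatter.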